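This account rests on a few compounds, and the source may have more. Where it says the series, first, only, none or still open, it means among the compounds named here.

Of the compounds shown here, three have been measured in a functional assay on KG-1 cells (Homo sapiens) for cytotoxicity, read by luminescence and CellTiter-Glo, with a stated time of 3 days; a lower number here means a stronger inhibitor, a higher number a weaker inhibitor. Compound 1 `N#Cc1ccc(NC(=O)c2cc(Cl)ccc2O)cc1` gives 1860 nM in this assay. Compound 3 `N#Cc1ccc(NC(=O)c2cc(C(F)(F)F)ccc2O)cc1` gives 4810 nM. Compound 2 `O=C(Nc1ccc(C(F)(F)F)cc1)c1ccc2cccnc2c1O` is built on a different core and gives 3510 nM; its number lies within the scatter of both compound 3 and compound 1, so no order among these three is claimed. The difference between the core of compound 2 and the core of compound 3 is not broken down here.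

One structural change recurs in this set. Between compound 3 and compound 1 it is chloro in place of trifluoromethyl on an aromatic carbon and the measured step is a 2.6-fold lower number from compound 3 to compound 1 (0.41 log units; beyond the scatter), a modest move beyond the scatter. Compound 4 `O=C(Nc1ccc(Cl)cc1)c1ccc2cccnc2c1O` has not yet been measured; it differs from compound 2 by chloro in place of trifluoromethyl on an aromatic carbon. The surroundings are not identical: in compound 4 the group sits para to a large group, whereas in compound 1 it sits meta to a large group and para to a hydroxy group. It is therefore the same kind of change rather than the same change, and it is carried into the core of compound 2 rather than the core of compound 3.

For the measured compounds named here, the expected step from compound 2 to compound 4 is a 2.3-fold lower number from compound 2 to compound 4 (0.37 log units; beyond the scatter), resting on the one measured instance a 2.6-fold lower number from compound 3 to compound 1 (0.41 log units; beyond the scatter) with a wider band for the change of core and setting. Compound 4 is accordingly estimated to give 1500 nM in this assay, expected to fall between 600 nM and 4000 nM.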

Compound 4, half-maximal inhibitory concentration: 3300 nM
Estimate against measurement, compound 4: 2.2-fold (0.34 log units) below, within the range that was stated.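

In this assay, the new step is a 1.1-fold lower number from compound 2 to compound 4 (0.03 log units; within the scatter), so on the core of compound 2 chloro in place of trifluoromethyl leaves the two numbers within the scatter of each other. Set beside the earlier step, the results on the two cores cannot be told apart: the same change on two cores in this assay, a 2.6-fold lower number (0.41 log units; beyond the scatter) from compound 3 to compound 1 and a 1.1-fold lower number (0.03 log units; within the scatter) from compound 2 to compound 4, 2.4-fold (0.39 log units) apart, within the scatter of two such steps. For the compounds shown here, this shows that the one step on the core of compound 3 gave no firm basis for expecting a clear step on the core of compound 2, but it does not show that the change behaves differently on the two cores, nor that it has one common size, as only two pairs are available and the group has different surroundings in each.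

The compounds shown leave open how an amine, a methoxy group or a carboxylic acid would compare with chloro and trifluoromethyl on an aromatic carbon para to a large group on the core of compound 2. They also leave open whether further pairs on either core would bring the size of this change into clearer view.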